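Inverting the saturated ring stereocentre of compound 1

The source may hold more compounds than are shown below. What is called first, only, known or untested is meant among the compounds shown, and "the series" means these compounds.

Compound 1 `CN1CCN(c2ccc(Nc3ncc4nc(Nc5ccc(F)cc5)n([C@@H]5CCN(C(=O)OC(C)(C)C)C5)c4n3)cc2)CC1` holds the lower of the two measured numbers in a functional assay on HCC827 cells (Homo sapiens) for antiproliferative activity, read by MTT assay, with a stated time of 72 h (on this read-out higher numbers stand for weaker inhibition and lower numbers for stronger inhibition), where compound 1 gives 27 nM. The other measured entry, compound 2 `CN1CCN(c2ccc(Nc3ncc4nc(Nc5ccccc5)n([C@@H]5CCNC5)c4n3)cc2)CC1`, sits higher in this assay, compound 2 giving 65 nM; the gap lies beyond the scatter, but the two compounds differ in more than one place, so only the two values themselves are noted. Among the compounds with values here, no pair of measured compounds differing in a single place exists, so the effect of any single change has not yet been observed.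

Compound 3 `CN1CCN(c2ccc(Nc3ncc4nc(Nc5ccc(F)cc5)n([C@H]5CCN(C(=O)OC(C)(C)C)C5)c4n3)cc2)CC1` keeps every atom and bond of compound 1; the change is the two compounds have the same atoms and bonds and differ only in configuration as drawn: 1 of 1 stereo elements differ; a stereocentre at a saturated ring carbon is drawn R in compound 1 and S in compound 3. Nothing in the measured pair shows what a change of configuration alone does here, and such a change could leave the number where it is or move it in either direction. The expectation leans toward a modest rise because compound 1 already gives 27 nM, the lower number of the set. Compound 3 is estimated at 70 nM, with a range from 18 nM to 300 nM. The expected step in this assay is a 2.6-fold higher number from compound 1 to compound 3 (0.41 log units; beyond the scatter), a loss beyond the scatter but held with low confidence.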

Compound 3, half-maximal inhibitory concentration: 580 nM
Compound 3: middle estimate off by 8.3-fold (0.92 log units), on the low side, outside the stated range (above it).
By their numbers in this assay, from the lowest: compound 1; then compound 2; then compound 3.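

In this assay, within the data shown here, the stereocentre at the saturated ring carbon is the first place where a single change can be read, and going from R to S gives a 21-fold higher number from compound 1 to compound 3 (1.33 log units; beyond the scatter), a large step beyond the scatter. The whole step can be assigned to that one stereocentre, because no other feature separates the pair: the fact that compounds 1 and 3 differ only in the configuration as drawn. The configuration at this carbon is therefore a strong determinant of the number in this assay, at least with the tert-butyl carbamate and the other substituents of compound 1 in place, with the R form holding the lower number and the S form the higher.

From the compounds shown here alone, whether a gap of this size persists when the tert-butyl carbamate gives way to another group on the ring nitrogen, such as an acetyl or a methanesulfonyl group, stays open, as does the size of the gap between the two configurations in the setting of compound 2. The compounds shown also give no reading of why a change of configuration alone moves the number this far, so the step stands as an observation on this one pair.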